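A few compounds are considered here, and "the series" means these few. Any claim that something is new, unique, unknown or untested is made for them only; others in the source may bear on it.

Measured compounds:
- Compound 1, `CCCCCCCCCCCC(=O)NCC(=O)N[C@@H]1[C@@H](O)[C@H](O)[C@@H](Nc2ncnc3[nH]cnc23)O[C@H]1C`: in a functional assay on L1210 cells (Mus musculus) for cytotoxicity (a lower number here means a stronger inhibitor, a higher number a weaker inhibitor), compound 1 gives > 10000 nM, which is a limit of the assay and not a number.
- Compound 2, `CC(C)CCCCCCCCCCCCC(=O)NCC(=O)N[C@@H]1[C@@H](O)[C@H](O)[C@@H](Nc2ncnc3[nH]cnc23)O[C@H]1CO`: in this assay compound 2 gives > 10000 nM, also a limit.
- Compound 3, `CCCCCCCCCCCC(=O)NCC(=O)N[C@@H]1[C@@H](O)[C@H](O)[C@@H](Nc2ncnc3[nH]cnc23)O[C@H]1CO`: in this assay compound 3 gives 3000 nM.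

Compound 1 therefore stands at the weak end of what is shown: it sits at the limit of > 10000 nM in this assay, at which 2 of the 3 values shown sit, so only a limit is known for it, and compound 3 is the only compound with an actual number. Both measured steps lead to compound 3 and lower the number, an at least 3.3-fold lower number from compound 1 to compound 3 (0.52 log units; beyond the scatter) and an at least 3.3-fold lower number from compound 2 to compound 3 (0.52 log units; beyond the scatter), each at least modest.

Compound 4, `CCCCCC(=O)NCC(=O)N[C@@H]1[C@@H](O)[C@H](O)[C@@H](Nc2ncnc3[nH]cnc23)O[C@H]1C`, differs from compound 1 in one place: hydrogen in place of hexyl on a saturated chain carbon, five bonds along the chain from a carbonyl carbon. Neither measured step touches the chain at this place; the step from compound 2 to compound 3 shortens the chain at its far end and lowers the number, but that compound carries the hydroxy group that compound 4, like compound 1, lacks. Compound 4 starts from a compound at the limit, so no movement beyond the scatter is expected; the step that the limit leaves unreadable from compound 1 to compound 4 is estimated to be flat. For compound 4 the expected value in this assay is 15000 nM, with a likely range of 5000 nM to 50000 nM.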

Compound 4, half-maximal inhibitory concentration: 250000 nM
For compound 4 the middle estimate is 17-fold (1.22 log units) below the measured one; the whole stated range lies below it.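

In this assay, going by these compounds alone, compound 1 gives > 10000 nM and that is a limit, so no step from compound 1 to compound 4 can be read: the limit of > 10000 nM in this assay, at which 2 of the 4 values shown sit. Still open, going by these compounds, is how far the number really moves when hexyl gives way to hydrogen on this chain, and what the hydroxy group of compound 3 would do on the shorter chain of compound 4.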